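Sulfur for Oxygen in the Sugar Ring of Compound 2

The source may hold more compounds than are shown below. What is called first, only, known or untested is meant among the compounds shown, and "the series" means these compounds.

Of the compounds shown here, two on a shared core have been measured in an assay on CHO cells for displacement of a labelled ligand from adenosine receptor A1 (Homo sapiens), with a stated time of 60 min, tested at 10 uM; on this read-out lower numbers stand for less inhibition and higher numbers for more inhibition at the one concentration tested (going by the name of the read-out). Compound 1 `CCCCC#Cc1nc(NCc2cccc(Cl)c2)c2ncn([C@@H]3SC[C@@H](O)[C@H]3O)c2n1` gives 25% in this assay, and compound 2 `CCCCC#Cc1nc(NCc2cccc(Br)c2)c2ncn([C@@H]3OC[C@@H](O)[C@H]3O)c2n1` gives 12%. Within the data shown here, compound 2 therefore stands lowest of the two numbers, with compound 1, its only neighbour, a number of percentage points higher and beyond the scatter. These two differ from each other in two places at once, so their values show only that much and no single step can be read from them.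

Compound 3 `CCCCC#Cc1nc(NCc2cccc(Br)c2)c2ncn([C@@H]3SC[C@@H](O)[C@H]3O)c2n1` is still to be measured. Among the measured compounds shown here, it differs from compound 2 in one place. 3,4-dihydroxythiolan-2-yl in place of 3,4-dihydroxyoxolan-2-yl on an aromatic nitrogen The thiolane ring is the one carried by compound 1, which gives 25% in this assay. A modest rise is expected, a number 10 percentage points higher from compound 2 to compound 3 (within the scatter), because compound 1 gives 25%. Compound 3 is accordingly estimated at 22%, with a likely range from 8% to 38%.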

Compound 3, a percentage reported as inhibition, at one concentration (the size of the read-out at that concentration, not a potency): 12%
For compound 3 the middle estimate is 10 percentage points above the measured one; the measured number falls inside the stated range.
By their numbers in this assay, from the lowest: compounds 2 and 3 (each within the scatter of the next); then compound 1.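

In this assay, 3,4-dihydroxythiolan-2-yl in place of 3,4-dihydroxyoxolan-2-yl on an aromatic nitrogen gives no change at the digits printed from compound 2 to compound 3 (within the scatter), so with the bromo group held constant, this exchange of the ring hetero atom leaves no difference that can be read. The other single-place comparison concerns the halogen: bromo in place of chloro on an aromatic carbon gives a number 13 percentage points lower from compound 1 to compound 3 (beyond the scatter), a step beyond the scatter that the two earlier compounds, differing in two places at once, could not isolate. No evidence at hand accounts for either step.

On these data alone, it remains open whether the halogen step would persist with 3,4-dihydroxyoxolan-2-yl on the aromatic nitrogen. As far as these compounds go, it is equally open how a methoxy group on that aromatic carbon, or an amine in place of a ring hydroxyl, would read in this assay.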